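Carbonyl substituent: methyl ester back to primary amide

This account rests on a few compounds, and the source may have more. Where it says the series, first, only, none or still open, it means among the compounds named here.

Two compounds of the series have been run in a functional assay on PANC-1 cells (Homo sapiens) for inhibition, read by Western blot, with a stated time of 24 h, tested at 50 uM; a higher number here means more inhibition at the concentration tested (going by the name of the read-out), a lower number less inhibition. Compound 1 `CNC(=O)c1ccccc1SC/C=C(\C)CC/C=C(\C)CCC=C(C)C` gives 39.7%. Going by the values given here, compound 2 `COC(=O)c1ccccc1SC/C=C(\C)CC/C=C(\C)CCC=C(C)C` gives 5.3%, the lower of the two numbers; its only neighbour is compound 1, separated from it by a number 34.4 percentage points lower from compound 1 to compound 2 (beyond the scatter). Among the compounds with values here, that single step, methoxy in place of methylamino on a carbonyl carbon, is the only measured change that bears on the next compound.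

Compound 3 `CC(C)=CCC/C(C)=C/CC/C(C)=C/CSc1ccccc1C(N)=O` has not yet been measured. It differs from compound 2 by amino in place of methoxy on a carbonyl carbon. The change runs back from the ester toward an amide, though the group entering is amino rather than methylamino, so the match with the measured step is not exact. With one step to go on, a rise of about the size seen on going to the ester is expected, in the opposite direction. For compound 3 in this assay the expected value is 36%, within 18% to 54%. The expected step is a number 30.7 percentage points higher from compound 2 to compound 3 (beyond the scatter).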

Compound 3, a percentage reported as inhibition, at one concentration (the size of the read-out at that concentration, not a potency): 37.4%
The estimate for compound 3 lay 1.4 percentage points below the measured number, within the range that was stated.
By their numbers in this assay, from the lowest: compound 2; then compounds 3 and 1 (each within the scatter of the next).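

The return from methyl ester to primary amide in this assay gives a number 32.1 percentage points higher from compound 2 to compound 3 (beyond the scatter), so the recovery at this carbonyl carbon does not depend on the methyl group of compound 1. The second comparison gives a number 2.3 percentage points lower from compound 1 to compound 3 (within the scatter), so hydrogen and methyl on the amide-type nitrogen cannot be told apart here, and the large change in this set of three comes with methoxy on the carbonyl carbon rather than with the choice between amino and methylamino. No measurement in hand explains why the ester stands apart from the two amides.

Still open, from the compounds shown here alone, is how a carboxylic acid or a dimethylamino group on the same carbonyl carbon would read, the latter being an amide with no hydrogen left on its nitrogen, and whether an ethyl group or a longer chain on that nitrogen would stay level with compound 1 and compound 3. These readings also come from a single concentration, so they give the size of the inhibition at that concentration and say nothing about the potency of compound 1 or compound 3.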